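Opening a ring into a short ether chain

The source may report more compounds than this note shows. Statements on the series, on what has been measured and on what is new or still open speak of the compounds shown alone.

Compound 3 `CC(=O)SCC(=O)c1ccc(NS(=O)(=O)c2ccc(OC3CCCN(C)C3)cc2)nc1` sits highest of the two numbers available in a functional assay on HCT-116 cells (Homo sapiens) for cytotoxicity (on this read-out lower numbers stand for an effect already at smaller amounts and higher numbers for an effect only at larger amounts of compound), where compound 3 gives 3700 nM. For the measured compounds named here, its nearest neighbour is compound 1 `CC(=O)SCC(=O)c1ccc(NS(=O)(=O)c2ccc(OCCCCN(C)C)cc2)nc1`, which in this assay gives 280 nM; the only measured step here is a 13-fold higher number from compound 1 to compound 3 (1.12 log units; beyond the scatter). Compound 2 `CC(=O)SCC(=O)c1ccc(NS(=O)(=O)c2ccc(OCCCc3ccccn3)cc2)nc1` carries a pyridinyl-propyl chain at the same position, but in this assay compound 2 gives "not determined" (no result reported).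

Compound 4 `COCCCOc1ccc(S(=O)(=O)Nc2ccc(C(=O)CSC(C)=O)cn2)cc1` is the next step: 3-methoxypropyl in place of 1-methylpiperidin-3-yl on an oxygen on an aromatic ring. Going by the values given here, the one step that bears on it is a 13-fold higher number from compound 1 to compound 3 (1.12 log units; beyond the scatter), in which an open chain on that oxygen was replaced by the same 1-methylpiperidin-3-yl ring that now leaves, and the number rose strongly. Compound 4 returns to an open chain, though a different one, so a return toward the lower number of compound 1 is expected, but with no chain of this kind measured the size is uncertain. Compound 4 is therefore estimated at 900 nM, within 200 nM to 4000 nM, which means an expected step of a 4.1-fold lower number from compound 3 to compound 4 (0.61 log units; beyond the scatter).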

Compound 4, half-maximal effective concentration: 5300 nM
For compound 4 the middle estimate is 5.9-fold (0.77 log units) below the measured one; measured number above the stated range.
By their numbers in this assay, from the lowest: compound 1; then compounds 3 and 4 (each within the scatter of the next).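

In this assay, putting an open chain back in place of the ring does not restore the low number: the change gives a 1.4-fold higher number from compound 3 to compound 4 (0.16 log units; within the scatter) and so leaves compound 4 level with compound 3. The other comparison is more informative, as methoxy in place of (dimethylamino)methyl on the chain gives a 19-fold higher number from compound 1 to compound 4 (1.28 log units; beyond the scatter) and stays beyond the scatter, so among these compounds an open chain alone does not go with the low number. Nor does a nitrogen alone, as compound 3 goes against that reading: it carries a nitrogen in its 1-methylpiperidin-3-yl ring and still sits with compound 4. Nothing available explains these differences.

Steps involving compound 2 cannot be read, as it has no reported result. Open questions are how a 3-(dimethylamino)propyl or 5-(dimethylamino)pentyl chain would behave, and whether a primary amine could stand in for the dimethylamino group.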